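Swapping Pyridin-4-yl for Methyl in Compound 1

This account rests on a few compounds, and the source may have more. Where it says the series, first, only, none or still open, it means among the compounds named here.

In a functional assay on HL-60 cells (Homo sapiens) for cytotoxicity, read by luminescence and CellTiter-Glo, with a stated time of 3 days (on this read-out higher numbers stand for weaker inhibition and lower numbers for stronger inhibition), compound 1 (`N#Cc1ccc(NC(=O)c2cc(-c3ccncc3)ccc2O)cc1`) gives 5410 nM and stands highest of three numbers, with compound 2 (`Cc1ccc(C(=O)Nc2ccc(C#N)cc2)c(O)c1`) at 2420 nM and compound 3 (`N#Cc1ccc(NC(=O)c2cc(Br)c3cccnc3c2O)cc1`) at 330 nM both lower beyond the scatter. Compound 4 (`Cc1ccc(O)c(C(=O)Nc2ccc(C#N)cc2)c1`) has methyl in place of pyridin-4-yl on an aromatic carbon. Within the data shown here, no measured pair shows this change alone. Compound 2, which also carries a methyl, gives 2420 nM and is the nearest number to compound 1, so a small move toward stronger inhibition is expected, probably not beyond the scatter. In this assay the estimated step is a 1.9-fold lower number from compound 1 to compound 4 (0.29 log units; within the scatter) in that direction. Compound 4 is therefore expected at 2800 nM (estimated range 1000 nM to 7000 nM).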

Compound 4, half-maximal inhibitory concentration: 3920 nM
Compound 4: middle estimate off by 1.4-fold (0.15 log units), on the low side; measured number inside the range.
By their numbers in this assay, from the lowest: compound 3; then compounds 2, 4 and 1 (each within the scatter of the next, the first and the last beyond it).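

In this assay, among these compounds, methyl in place of pyridin-4-yl on an aromatic carbon para to a hydroxy group gives a 1.4-fold lower number from compound 1 to compound 4 (0.14 log units; within the scatter), the first single-change step at this position. On this read-out, then, the six-membered aromatic ring of pyridin-4-yl and the much smaller methyl cannot be told apart at this carbon. Nothing available explains this result. The compounds shown leave open whether an amine, a carboxylic acid or a longer chain on this carbon would shift the number beyond the scatter.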